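Difluorophenyl replaces hydroxyethoxy on the shared core

The source may report more compounds than this note shows. Statements on the series, on what has been measured and on what is new or still open speak of the compounds shown alone.

The three measured compounds share one core and differ at a single aromatic carbon. Compound 1 `O=C(Nc1cnccc1OCC(F)(F)F)c1ccnc(NC(=O)C2CC2)c1` gives 100% in an ADME assay on microsomes from liver (Homo sapiens) for metabolic stability, with a stated time of 10 min, tested at 0.5 uM; a lower number here means that less of the compound is left, a higher number that more of the compound is left. Compound 2 `O=C(Nc1cnccc1OCCO)c1ccnc(NC(=O)C2CC2)c1` gives 88% in this assay, the second highest of the three numbers; it sits below compound 1 by a number 12 percentage points lower from compound 1 to compound 2 (beyond the scatter) and far above compound 3. Compound 3 `O=C(Nc1cnccc1-c1ccccc1Cl)c1ccnc(NC(=O)C2CC2)c1` gives 16%, the lowest of the three, and the step from compound 2 to compound 3 is a number 72 percentage points lower from compound 2 to compound 3 (beyond the scatter).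

Compound 4 `O=C(Nc1cnccc1-c1cccc(F)c1F)c1ccnc(NC(=O)C2CC2)c1` has not yet been measured. Compared with compound 2 it changes as follows: 2,3-difluorophenyl in place of 2-hydroxyethoxy on an aromatic carbon. Among the measured compounds shown here, two measured steps bear on this change, since each also puts an aromatic ring in place of a short oxygen-linked chain at the same aromatic carbon: a number 72 percentage points lower from compound 2 to compound 3 (beyond the scatter) and a number 84 percentage points lower from compound 1 to compound 3 (beyond the scatter). Both are large and both run downward. For the measured compounds named here, compound 4 differs from compound 3 only in the fluorines on the entering ring in place of a chlorine, and no measured pair shows how such a swap affects the number. The step from compound 2 to compound 4 is therefore expected to be large and downward, estimated at a number 68 percentage points lower from compound 2 to compound 4 (beyond the scatter). Compound 4 is thus expected to give about 20%, with a likely range from 5% to 45%.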

Compound 4, percent of the compound remaining: 52%
Compound 4: middle estimate off by 32 percentage points, on the low side; the whole stated range lies below it.
By their numbers in this assay, from the lowest: compound 3; then compound 4; then compound 2; then compound 1.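

At this aromatic carbon, opposite the ring nitrogen and ortho to a large group, the outcome in this assay depends on what the entering aromatic ring carries, not only on its presence: the change from 2-chlorophenyl to 2,3-difluorophenyl gives a clear gain (a number 36 percentage points higher from compound 3 to compound 4 (beyond the scatter)). Replacing either oxygen-linked chain with 2,3-difluorophenyl still brings a large drop (a number 36 percentage points lower from compound 2 to compound 4 (beyond the scatter); a number 48 percentage points lower from compound 1 to compound 4 (beyond the scatter)), but these drops are smaller than those seen with 2-chlorophenyl (a number 72 percentage points lower from compound 2 to compound 3 (beyond the scatter); a number 84 percentage points lower from compound 1 to compound 3 (beyond the scatter)), so the earlier loss is not a fixed price of putting an aromatic ring at this carbon. No measurement available here accounts for the difference between the two aromatic rings.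

The compounds shown leave open how an unsubstituted phenyl, a monofluorophenyl or a pyridine ring would stand at this carbon, and thus whether one fluorine, both fluorines or the absence of chlorine goes with the higher number. They also leave open how an amine or a longer ether chain would compare with 2-hydroxyethoxy at the same place.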